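The source may report more compounds than this note shows. Statements on the series, on what has been measured and on what is new or still open speak of the compounds shown alone.

Compound 1 `O=C(CCCC1CCN(C(=O)c2ccccc2)CC1)c1ncco1` and compound 2 `O=C(CCCC1CCN(S(=O)(=O)Cc2ccccc2)CC1)c1ncco1` share a core and differ only in the group carried on the ring nitrogen. In an assay on isolated protein for inhibition of Fatty-acid amide hydrolase 1 (Homo sapiens) (on this read-out higher numbers stand for weaker inhibition and lower numbers for stronger inhibition), compound 1 gives 77 nM, the lowest of the two numbers shown, and compound 2 gives 600 nM; the gap between those two values is wider than the usual scatter of repeated measurements.

Compound 3 `Cc1cccc(CN2CCC(CCCC(=O)c3ncco3)CC2)c1` has not yet been measured in this assay. Compared with compound 1 it differs at a single site: 3-methylbenzyl in place of benzoyl on an amine nitrogen in a ring. Among the measured compounds shown here, the change keeps the ring nitrogen but removes the carbonyl that compound 1 carries there; there is no measured pair in the set that reports this kind of exchange, so only the distance between compound 1 and compound 2 offers any guide to how much a change at that nitrogen can shift the number.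

On that basis compound 3 is expected to return a higher number than compound 1, with an estimated step of a 13-fold higher number from compound 1 to compound 3 (1.11 log units; beyond the scatter). The value of compound 3 in this assay is estimated at 1000 nM, in a range from 200 nM to 5000 nM.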

Compound 3, half-maximal inhibitory concentration: 90 nM
For compound 3 the middle estimate is 11-fold (1.05 log units) above the measured one; measured number below the stated range.
By their numbers in this assay, from the lowest: compounds 1 and 3 (each within the scatter of the next); then compound 2.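

In this assay the exchange of benzoyl for 3-methylbenzyl on the amine nitrogen in the ring gives a 1.2-fold higher number from compound 1 to compound 3 (0.07 log units; within the scatter) and so leaves the number within the scatter, even though the carbonyl and the one hydrogen-bond acceptor of benzoyl are gone. At this position, then, a group with a six-membered aromatic ring of carbon only and no carbonyl stands level with benzoyl, so the higher number of compound 2, at 600 nM, cannot be read as a general result of replacing benzoyl on this nitrogen. No measurement among those shown explains why the exchange in compound 3 leaves the number within the scatter.

The compounds shown leave open whether plain benzyl, without the methyl group, would stand with compound 1 and compound 3, and whether the methyl group matters at all on this ring. They also leave open how this read-out would respond to a longer chain such as phenylethyl on the same nitrogen, or to a carboxylic acid or an amine on the aromatic ring.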